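The source may hold more compounds than are shown below. What is called first, only, known or untested is meant among the compounds shown, and "the series" means these compounds.

Working notes on the series. In a functional assay on NCI-H226 cells (Homo sapiens) for cytotoxicity, read by sulforhodamine B assay, with a stated time of 48 h, tested at 1 uM (on this read-out higher numbers stand for a weaker effect at the one concentration tested and lower numbers for a stronger effect), compound 1 `COc1cc(-c2cc(/C=C/C(=O)c3ccc(N)cc3)[nH]n2)cc(OC)c1OC` gives 88%, compound 2 `COc1ccc(C(=O)/C=C/c2cc(-c3cc(OC)c(OC)c(OC)c3)n[nH]2)cc1OC` gives 89%, and compound 3 `COc1ccc(C(=O)/C=C/c2cc(-c3cc(OC)c(OC)c(OC)c3)n[nH]2)cc1` gives 92%; all three sit within the scatter of one another, so no order among them can be read. The cores of compound 1 and compound 2 differ by 4-aminophenyl in place of 3,4-dimethoxyphenyl on a carbonyl carbon. Compound 4 `COc1ccc(-c2cc(/C=C/C(=O)c3ccc(N)cc3)[nH]n2)cc1OC` is not yet measured in this assay; it differs from compound 1 by hydrogen in place of methoxy on an aromatic carbon. The same kind of change, (hydrogen in place of methoxy on an aromatic carbon), made from compound 2 to compound 3 gave a number 3 percentage points higher from compound 2 to compound 3 (within the scatter); the places are not identical, since in compound 4 the place is also meta to a methoxy group. Because the step of a number 3 percentage points higher from compound 2 to compound 3 (within the scatter) lies within the scatter, the step to compound 4 is expected to be a number 2 percentage points higher from compound 1 to compound 4 (within the scatter). Compound 4 is therefore estimated at 90% in this assay, between 81% and 98%.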

Compound 4, a percentage reported as activity, at one concentration (the size of the read-out at that concentration, not a potency): 86%
The estimate for compound 4 lay 4 percentage points above the measured number, and the stated range covers the measured number.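

In this assay, hydrogen in place of methoxy on an aromatic carbon gives a number 2 percentage points lower from compound 1 to compound 4 (within the scatter). Set beside the earlier case, the two cores show no detectable difference in the outcome of this change: the same change on two cores in this assay, a number 3 percentage points higher (within the scatter) from compound 2 to compound 3 and a number 2 percentage points lower (within the scatter) from compound 1 to compound 4, 5 percentage points apart, within the scatter of two such steps. This shows that the change can be carried between these two cores without a readable shift at the one concentration tested, but it does not show that the two steps are equal, nor that the change would behave the same at other concentrations or on other cores.

The compounds shown leave open how a hydroxyl group or a longer alkoxy chain such as ethoxy would read at this place. Also open, from the compounds shown here alone, is whether a carboxylic acid in place of the amino group of compound 1 would move the read-out.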